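A Second Aryl Swap on a Quinoline Sulfone Core

The compounds below may be only part of what the source reports. "The series", "measured", "known", "first", "only" and "open" are said of these compounds alone.

Of the compounds shown here, two of a shared core have been measured in an ADME assay on microsomes from liver (Homo sapiens) for metabolic stability, tested at 2.5 uM; on this read-out lower numbers stand for slow clearance and higher numbers for fast clearance. Compound 1 `O=S(=O)(c1cc(Cl)cc(Cl)c1)c1cnc2c(F)cccc2c1-c1cccc(Cl)c1` gives 1.2 mL/min in this assay, the lower of the two numbers. Among the compounds with values here, compound 2 `COc1ccc(S(=O)(=O)c2cnc3c(F)cccc3c2-c2cccc(Cl)c2)cc1` gives 2.75 mL/min in this assay; the only change, a 2.3-fold higher number from compound 1 to compound 2 (0.36 log units; beyond the scatter), sits on the sulfonyl sulfur.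

Compound 3 `O=S(=O)(c1cc(Cl)cc(Cl)c1)c1cnc2c(F)cccc2c1-c1ccccc1F` differs from compound 1 elsewhere: 2-fluorophenyl in place of 3-chlorophenyl on an aromatic carbon. Within the data shown here, no measured step touches this position, so the one known step, on the sulfonyl sulfur, does not bear on it directly; it only shows that a change of a pendant ring can move the number beyond the scatter. With nothing at this position to go on, the expectation for compound 3 is a step of a 1.3-fold higher number from compound 1 to compound 3 (0.10 log units; within the scatter), not clearly beyond the scatter. Compound 3 is therefore estimated at 1.5 mL/min in this assay, within a range from 0.6 mL/min to 3.5 mL/min.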

Compound 3, intrinsic clearance in a liver preparation (reported as CLH), per the amount of preparation that the assay uses: 0.44 mL/min
Beside the measured number, compound 3's estimate is 3.4-fold (0.53 log units) above it; the whole stated range lies above it.
By their numbers in this assay, from the lowest: compound 3; then compound 1; then compound 2.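

In this assay the ring on this aromatic carbon proves to matter: 2-fluorophenyl in place of 3-chlorophenyl gives a 2.7-fold lower number from compound 1 to compound 3 (0.44 log units; beyond the scatter) and so moves the number beyond the scatter. The shared core therefore has a second place where one change shifts the number, and this shift points toward slower clearance, while the change on the sulfonyl sulfur, (a 2.3-fold higher number from compound 1 to compound 2 (0.36 log units; beyond the scatter)), points toward faster clearance. Nothing available here gives a reason for the lower number of compound 3.

The swap changes both the halogen and its place on the ring, and the compounds shown do not tell these two apart. On these data alone, how this position would respond to a ring carrying an amine or a carboxylic acid also remains open.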